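The compounds below may be only part of what the source reports. "The series", "measured", "known", "first", "only" and "open" are said of these compounds alone.

Of the compounds shown here, three sharing one core have been measured in a functional assay on CHO cells for agonist activity at Free fatty acid receptor 1 (Homo sapiens), read by FLIPR and calcium flux, in the presence of a further agent that is not named here; on this read-out higher numbers stand for an effect only at larger amounts of compound and lower numbers for an effect already at smaller amounts. Compound 1 `O=C(O)CCc1ccc(OCc2nc(-c3ccccc3)no2)cc1` gives 1130 nM, compound 2 `O=C(O)CCc1ccc(OCc2nc(-c3ccc(F)cc3)no2)cc1` gives 680 nM, and compound 3 `Cc1ccc(-c2noc(COc3ccc(CCC(=O)O)cc3)n2)cc1` gives 300 nM. Compound 3 thus stands lowest of the three numbers, reached by a 3.8-fold lower number from compound 1 to compound 3 (0.58 log units; beyond the scatter) and by a 2.3-fold lower number from compound 2 to compound 3 (0.36 log units; beyond the scatter), both beyond the scatter, whereas a 1.7-fold lower number from compound 1 to compound 2 (0.22 log units; within the scatter) stayed within it. Compound 4 `O=C(O)CCc1ccc(OCc2nc(-c3ccc(C(F)(F)F)cc3)no2)cc1` is not yet measured; it differs from compound 3 by trifluoromethyl in place of methyl on an aromatic carbon. The three measured steps all concern the same aromatic carbon and therefore bear on this change: the two that replaced hydrogen or fluoro by methyl lowered the number modestly, and the hydrogen to fluoro change gave nothing beyond the scatter. On that basis, for compound 4 the expected step is a 1.5-fold lower number from compound 3 to compound 4 (0.18 log units; within the scatter), a slight lowering at most and not one beyond the scatter. Compound 4 is estimated to give 200 nM in this assay, with a range from 60 nM to 650 nM.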

Compound 4, half-maximal effective concentration: 610 nM
Compound 4: middle estimate off by 3.1-fold (0.48 log units), on the low side; low and high end bracket the measured number.
By their numbers in this assay, from the lowest: compound 3; then compounds 4, 2 and 1 (each within the scatter of the next).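

In this assay, the lowering seen with methyl does not carry over to trifluoromethyl on this aromatic carbon, para to a large group: the change gives a 2.0-fold higher number from compound 3 to compound 4 (0.31 log units; beyond the scatter), so these two groups can be told apart here. Trifluoromethyl cannot be separated from the other two groups at this carbon, since a 1.1-fold lower number from compound 2 to compound 4 (0.05 log units; within the scatter) and a 1.9-fold lower number from compound 1 to compound 4 (0.27 log units; within the scatter) both stay within the scatter. Of the four groups, only methyl now stands apart, with compound 3 beyond the scatter of compounds 1, 2 and 4, so going from methyl to the larger trifluoromethyl does not extend its gain.

Going by these compounds, whether an ethyl group, a methoxy group or a chlorine atom on this carbon would track methyl or trifluoromethyl remains open. Nothing measured here bears on why methyl stands apart.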